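Chloro for Methyl on the Aryl Ring of Compound 2

A few compounds are considered here, and "the series" means these few. Any claim that something is new, unique, unknown or untested is made for them only; others in the source may bear on it.

Measured so far:
compound 1 `CN(C)c1ccc2c(=O)c(C(=O)Nc3cc(F)cc(F)c3)cn(-c3ccc(Cl)c(OCCCCCCC[N+]45CCN(CC4)CC5)c3)c2n1` — 8.08%
compound 2 `Cc1ccc(-n2cc(C(=O)Nc3cc(F)cc(F)c3)c(=O)c3ccc(N(C)C)nc32)cc1OCCCCCCC[N+]1(C)CCCCC1` — 23.4%

Of the compounds shown here, two have been tested in an assay on LX2 cells for inhibition of COL1A1 promoter (Homo sapiens), read by a luciferase reporter, with a stated time of 24 h, tested at 20 uM; on this read-out lower numbers stand for a weaker effect and higher numbers for a stronger effect at the one concentration tested. Compound 1 `CN(C)c1ccc2c(=O)c(C(=O)Nc3cc(F)cc(F)c3)cn(-c3ccc(Cl)c(OCCCCCCC[N+]45CCN(CC4)CC5)c3)c2n1` gives 8.08% in this assay, while compound 2 `Cc1ccc(-n2cc(C(=O)Nc3cc(F)cc(F)c3)c(=O)c3ccc(N(C)C)nc32)cc1OCCCCCCC[N+]1(C)CCCCC1` gives 23.4%, the higher of the two numbers, and the gap from compound 1 to compound 2 lies beyond the scatter. Compound 3 `CN(C)c1ccc2c(=O)c(C(=O)Nc3cc(F)cc(F)c3)cn(-c3ccc(Cl)c(OCCCCCCC[N+]4(C)CCCCC4)c3)c2n1` has not yet been measured. It differs from compound 2 in one place only: chloro in place of methyl on an aromatic carbon, on an aromatic carbon of a six-membered aromatic ring of carbon only. Going by the values given here, no measured pair shows what a swap of this kind does in this assay, so there is no step to lean on. Given that compound 2 gives 23.4%, the step of a number 3.4 percentage points lower from compound 2 to compound 3 (within the scatter) is expected to be small and most likely not beyond the scatter. Compound 3 is therefore estimated at 20%, within 5% to 36%.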

Compound 3, a percentage reported as inhibition, at one concentration (the size of the read-out at that concentration, not a potency): 57.3%
Compound 3: middle estimate off by 37.3 percentage points, on the low side; the measured number lies above the stated range.
By their numbers in this assay, from the lowest: compound 1; then compound 2; then compound 3.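

In this assay, going by these compounds alone, the place on the aromatic ring ortho to a large group and para to a large group proves sensitive: chloro in place of methyl gives a number 33.9 percentage points higher from compound 2 to compound 3 (beyond the scatter), the first single-place change that can be read in this assay. The end of the saturated chain matters as well, with chloro held on the ring: a group of 7 heavy atoms with one six-membered non-aromatic ring, in place of a group of 8 heavy atoms with 2 such rings, gives a number 49.2 percentage points higher from compound 1 to compound 3 (beyond the scatter). No accompanying measurement explains either step.

The compounds shown leave open whether bromo, fluoro or methoxy at this ring place would read like chloro or like methyl. They also leave open whether the step from methyl to chloro keeps its size with the group of 8 heavy atoms, or with a shorter or longer chain.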